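The source may hold more compounds than are shown below. What is called first, only, known or untested is meant among the compounds shown, and "the series" means these compounds.

In a functional assay on KB cells (Homo sapiens) for cytotoxicity (on this read-out higher numbers stand for an effect only at larger amounts of compound and lower numbers for an effect already at smaller amounts), compound 1 (`COC1=C(C)C(=O)/C(=C(O)/C=C/c2ccc(OC)cc2)C(=O)C1(C)C`) gives 3.6 ug/mL and compound 2 (`COC1=C(C)C(=O)/C(=C(O)/C=C/c2ccccc2OC)C(=O)C1(C)C`) gives 3.3 ug/mL, while compound 3 (`COC1=C(C)C(=O)/C(=C(O)/C=C/c2cc(C)cc(C)c2)C(=O)C1(C)C`) gives 3.1 ug/mL on the same shared core. Compound 3 thus stands level with the other two, as its number lies within the usual scatter of both.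

The next compound, compound 4 (`COC1=C(C)C(=O)/C(=C(O)/C=C/c2cccs2)C(=O)C1(C)C`), keeps that core but carries thiophen-2-yl in place of 3,5-dimethylphenyl on a double-bonded chain carbon bound to a double-bonded chain carbon. Three measured steps changed the group at this same place: (a 1.1-fold lower number from compound 1 to compound 2 (0.04 log units; within the scatter)) and (a 1.2-fold lower number from compound 1 to compound 3 (0.06 log units; within the scatter)) and (a 1.1-fold lower number from compound 2 to compound 3 (0.03 log units; within the scatter)). All three stayed within the scatter. None of them, however, brought in thiophen-2-yl, so they guide the expectation without settling it.

No step beyond the scatter is expected in this assay, and the expected step is small (a 1.1-fold higher number from compound 3 to compound 4 (0.03 log units; within the scatter)). For compound 4 the estimate is 3.3 ug/mL with an expected range from 1.7 ug/mL to 6.5 ug/mL in this test.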

Compound 4, concentration for half-maximal effect: 5.5 ug/mL
For compound 4 the middle estimate is 1.7-fold (0.22 log units) below the measured one, within the range that was stated.
By their numbers in this assay, from the lowest: compounds 3, 2, 1 and 4 (each within the scatter of the next).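

In this assay, the result shows that the ring at this place need not be a phenyl group: thiophen-2-yl, a five-membered aromatic ring with a sulfur atom, stays within the scatter of all three phenyl-bearing compounds (a 1.8-fold higher number from compound 3 to compound 4 (0.25 log units; within the scatter) and a 1.7-fold higher number from compound 2 to compound 4 (0.22 log units; within the scatter) and a 1.5-fold higher number from compound 1 to compound 4 (0.18 log units; within the scatter)). The change from 3,5-dimethylphenyl, with 8 heavy atoms, to thiophen-2-yl, with 5, therefore gives no step beyond the scatter, even though both the ring size and the ring atoms differ. No measurement here offers an explanation for the size of these steps.

Going by these compounds, all four compounds carry an aromatic ring at this place, so it remains open whether an amine, a carboxylic acid or a longer alkyl chain there would give a step beyond the scatter. On these data alone, the effect of changes elsewhere on the shared core also remains open.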